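The compounds below may be only part of what the source reports. "The series", "measured", "known", "first", "only" and "open" are said of these compounds alone.

Measured in a functional assay on MCF7 cells (Homo sapiens) for cytotoxicity, read by MTT assay, with a stated time of 72 h; a higher number here means a weaker inhibitor, a lower number a stronger inhibitor:
- compound 1 `CNC(=O)c1cc(Oc2ccc(C(=O)/C=C/c3ccc([N+](=O)[O-])cc3)cc2)ccn1`: "not determined" (no result reported)
- compound 2 `CNC(=O)c1cc(Oc2ccc(C(=O)/C=C/c3ccc(F)cc3)cc2)ccn1`: 28500 nM
- compound 3 `CNC(=O)c1cc(Oc2ccc(C(=O)/C=C/c3ccc(OC)cc3)cc2)ccn1`: "not determined" (no result reported)

The series offers little to work from. In this assay compound 3 stands at "not determined" (no result reported), so it has no single number, and compound 1 likewise stands at "not determined" (no result reported). Only compound 2 gives a number, at 28500 nM.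

The next compound is compound 4 `CNC(=O)c1cc(Oc2ccc(C(=O)/C=C/c3cccc([N+](=O)[O-])c3)cc2)ccn1`. The change is 3-nitrophenyl in place of 4-methoxyphenyl on a double-bonded chain carbon bound to a double-bonded chain carbon.

Among the measured compounds shown here, no measured step shows what such a change does, and compound 3 offers no starting number. For the measured compounds named here, the only anchor is compound 2 at 28500 nM. Compound 4 is therefore expected to read close to that value in this assay, with no step in either direction beyond the scatter. For compound 4 the estimated value is 22000 nM, with an expected range from 8000 nM to 55000 nM.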

Compound 4, half-maximal inhibitory concentration: > 50000 nM
Compound 4 was reported as a limit; the forecaster's own chance of this, stated with the estimate: 15%; at least 2.2-fold (0.35 log units) between middle value and limit.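

Compound 4 carries a limit, not a number: the limit of > 50000 nM in this assay, at which 1 of the 4 values shown sits.

Putting 3-nitrophenyl in place of 4-fluorophenyl, on a double-bonded chain carbon bound to a double-bonded chain carbon, gives an at least 1.7-fold higher number from compound 2 to compound 4 (0.24 log units; that floor lies within the scatter). Among the compounds shown here, this is the first comparison available at this position, and it shows no gain in cytotoxicity in this assay, though the size of any loss stays unknown; the steps to compound 1 and compound 3 cannot be read.

From the compounds shown here alone, compound 1 offers no number to set against compound 4, so the effect of moving the nitro group on the ring remains open. The compounds shown also leave open whether an amine or a carboxylic acid on this ring would bring the number below that of compound 2.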